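The source may hold more compounds than are shown below. What is called first, only, known or untested is meant among the compounds shown, and "the series" means these compounds.

Series notes. Compound 1 `CN(C(=O)NC(=O)c1ccccc1F)c1nc(C(F)(F)F)c(C(=O)N/N=C/c2ccccc2C(F)(F)F)s1` and compound 2 `CN(C(=O)NC(=O)c1cccc([N+](=O)[O-])c1)c1nc(C(F)(F)F)c(C(=O)N/N=C/c2ccccc2C(F)(F)F)s1` share one core and differ only in the group on a carbonyl carbon. In a functional assay on MCF7 cells (Homo sapiens) for inhibition, read by MTT assay, with a stated time of 72 h (on this read-out lower numbers stand for stronger inhibition and higher numbers for weaker inhibition), compound 1 gives 12.2 ug/mL. In this assay compound 2 gives 4.73 ug/mL. The step of a 2.6-fold lower number from compound 1 to compound 2 (0.41 log units; beyond the scatter) is the only one measured so far; it leaves compound 2 with the lowest number of the two, compound 1 standing that step above it.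

Compound 3 `CN(C(=O)NC(=O)c1ccc(C(F)(F)F)cc1)c1nc(C(F)(F)F)c(C(=O)N/N=C/c2ccccc2C(F)(F)F)s1` is not yet measured. The change from compound 2 is 4-(trifluoromethyl)phenyl in place of 3-nitrophenyl on a carbonyl carbon. Among the measured compounds shown here, no measured step covers this exchange: the one step that exists, a 2.6-fold lower number from compound 1 to compound 2 (0.41 log units; beyond the scatter), concerns a different pair of groups at the same carbonyl carbon and shows only that exchanging the group there can move the number beyond the scatter; it gives no direction for a 4-(trifluoromethyl)phenyl. The expected step in this assay is a 1.6-fold higher number from compound 2 to compound 3 (0.20 log units; within the scatter), that is a change of modest size at most, and more likely toward a higher number than toward a lower one. Compound 3 is estimated at 7.5 ug/mL, with a range from 3 ug/mL to 18 ug/mL.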

Compound 3, half-maximal inhibitory concentration: 2.21 ug/mL
For compound 3 the middle estimate is 3.4-fold (0.53 log units) above the measured one, and the stated range ends above it.
By their numbers in this assay, from the lowest: compound 3; then compound 2; then compound 1.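

At this carbonyl carbon, the step of a 2.1-fold lower number from compound 2 to compound 3 (0.33 log units; beyond the scatter) in this assay shows that the number can go lower still once the 3-nitrophenyl is gone, so the hydrogen-bond acceptors counted on that group are not required for the lowest number in this set. Together with the larger step of a 5.5-fold lower number from compound 1 to compound 3 (0.74 log units; beyond the scatter), this gives the position a three-member order that lies beyond the scatter at each step, with compound 3 lowest, compound 2 in the middle and compound 1 highest. No evidence on hand accounts for this order.

Each exchange alters both the substituent and its printed ring position, so the three compounds cannot separate the identity of the substituent from where it sits, and a matched pair such as 3-(trifluoromethyl)phenyl and 4-(trifluoromethyl)phenyl, or 3-nitrophenyl and 4-nitrophenyl, would be needed to do so. Also open, on these data alone, is how an unsubstituted phenyl, a 4-aminophenyl or a 4-carboxyphenyl would stand at this carbonyl carbon, and whether the order holds with a different group elsewhere on the shared core.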